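From compound 3 to compound 4: amide nitrogen substituent

A few compounds are considered here, and "the series" means these few. Any claim that something is new, unique, unknown or untested is made for them only; others in the source may bear on it.

Values in a functional assay on MCF7 cells (Homo sapiens) for antiproliferative activity, read by MTT assay, with a stated time of 72 h (a higher number here means a weaker inhibitor, a lower number a stronger inhibitor), so far:
compound 1 `CCn1c(C(=O)NCCC(=O)OC)ccc1C(CC)(CC)c1ccc(C#CC(O)(CC)CC)c(C)c1` gives > 50000 nM (a limit)
compound 2 `CCCCC(=O)c1ccc(C(CC)(CC)c2ccc(C#CC(O)(CC)CC)c(C)c2)n1CC` gives > 50000 nM (a limit)
compound 3 `CCn1cc(C(CC)(CC)c2ccc(C#CC(O)(CC)CC)c(C)c2)cc1C(=O)NCC(=O)OC` gives 26500 nM (a number)

Going by the values given here, compound 3 alone carries a number, 26500 nM in this assay (the only reading of its kind). Compound 1 and compound 2 show only the limit of > 50000 nM in this assay, at which 2 of the 3 values shown sit, and no number.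

Compound 4 `CCn1cc(C(CC)(CC)c2ccc(C#CC(O)(CC)CC)c(C)c2)cc1C(=O)N[C@H](C(=O)O)C(C)C` is next to be read. The difference is 1-carboxy-2-methylpropyl in place of (methoxycarbonyl)methyl on an amide-type nitrogen and amounts to 1-carboxy-2-methylpropyl in place of (methoxycarbonyl)methyl on an amide-type nitrogen.

Among the compounds with values here, the one measured step is a step that the two limits leave unreadable from compound 1 to compound 2 and concerns a group on a carbonyl carbon, so it offers no size to carry over. Within the data shown here, no measured step covers this change, so the expectation stays anchored on compound 3 at 26500 nM (no direction can be supported). The expected result is a 1.3-fold lower number from compound 3 to compound 4 (0.12 log units; within the scatter) (not beyond the scatter). For compound 4 the estimate is 20000 nM (expected range 4000 nM to 50000 nM).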

Compound 4, half-maximal inhibitory concentration: 12600 nM
Estimate against measurement, compound 4: 1.6-fold (0.20 log units) above; measured number inside the range.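

In this assay, going by these compounds alone, the amide-type nitrogen gives the first readable step, a 2.1-fold lower number from compound 3 to compound 4 (0.32 log units; beyond the scatter), so this position responds measurably, though only modestly, to a change of substituent. Within the data shown here, the change is a combined one: 1-carboxy-2-methylpropyl brings a free carboxy group, a branched chain and a defined stereocentre together in place of (methoxycarbonyl)methyl, and the single step does not apportion its size among them. The step between compound 1 and compound 2 cannot be read, since both values are limits, so no second step is available for comparison: the limit of > 50000 nM in this assay, at which 2 of the 4 values shown sit.

Still open, as far as these compounds go, is whether the carboxy group or the branched chain accounts for the step; carboxymethyl and 1-(methoxycarbonyl)-2-methylpropyl on the same nitrogen would separate the two. From the compounds shown here alone, the opposite stereocentre of the 1-carboxy-2-methylpropyl group also remains open.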